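The source may report more compounds than this note shows. Statements on the series, on what has been measured and on what is new or still open speak of the compounds shown alone.

Measured compounds:
- Compound 1 `COc1cc(OCc2cccc(-c3ccc(C#N)cc3)c2)c2cc(-c3cn4nc(OC)sc4n3)oc2c1`: in an ADME assay on microsomes from liver (Rattus norvegicus) for metabolic stability (a higher number here means that the compound lasts longer, a lower number that the compound disappears faster), compound 1 gives 1.67 h.
- Compound 2 `COc1cc(OCc2cccc(-c3ccc(OC)nc3)c2)c2cc(-c3cn4nc(OC)sc4n3)oc2c1`: in this assay compound 2 gives 0.633 h.

The two compounds share one core and differ only in the aromatic group at the end of the benzyl arm. Going by the values given here, the single step in this assay is a 2.6-fold lower number from compound 1 to compound 2 (0.42 log units; beyond the scatter), so compound 2 stands at the lower of the two numbers, with compound 1 the only neighbour.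

Compound 3 `COc1cc(OCc2cccc(-c3cnc(OC)cn3)c2)c2cc(-c3cn4nc(OC)sc4n3)oc2c1` takes the next step from compound 2: 5-methoxypyrazin-2-yl in place of 6-methoxypyridin-3-yl on an aromatic carbon. Among the compounds with values here, the one measured step swapped a 4-cyanophenyl for a 6-methoxypyridin-3-yl and does not cover the change from compound 2 to compound 3, which keeps the methoxy group and adds a second ring nitrogen. Within the data shown here, no step in the data bears directly on it, so the expectation rests on compound 2 alone, with a wide range.

The change from compound 2 to compound 3 is expected to be a 1.1-fold higher number from compound 2 to compound 3 (0.04 log units; within the scatter), that is, no step beyond the scatter in either direction. In this assay compound 3 is therefore estimated at 0.7 h, with a range from 0.35 h to 1.4 h.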

Compound 3, half-life: 1.62 h
Compound 3: middle estimate off by 2.3-fold (0.36 log units), on the low side, outside the stated range (above it).
By their numbers in this assay, from the lowest: compound 2; then compounds 3 and 1 (each within the scatter of the next).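

In this assay, replacing 6-methoxypyridin-3-yl with 5-methoxypyrazin-2-yl gives a 2.6-fold higher number from compound 2 to compound 3 (0.41 log units; beyond the scatter), so at this position, on the ring at the end of the benzyl arm, a second ring nitrogen goes with a step beyond the scatter even though the methoxy group stays and the heavy-atom count is unchanged. The other new comparison, a 1.0-fold lower number from compound 1 to compound 3 (0.01 log units; within the scatter), lies within the scatter, so 5-methoxypyrazin-2-yl and 4-cyanophenyl cannot be told apart here, and of these three compounds only compound 2, with its 6-methoxypyridin-3-yl group, stands apart on the low side. Nothing at hand explains why this ring change goes with this difference in half-life.

The three compounds leave open whether the methoxy group matters to the number at all, as each methoxy-bearing ring here has that same group in the same place. As far as these compounds go, how an amine, a longer ether chain or a plain hydrogen in place of that methoxy group on the 5-methoxypyrazin-2-yl ring would compare also remains open.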